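One group exchanged on a shared core

This account rests on a few compounds, and the source may have more. Where it says the series, first, only, none or still open, it means among the compounds named here.

In a physicochemical assay for solubility, read by LC-MS, in phosphate buffer, with a stated time of 24 h, at pH 7.4 (on this read-out higher numbers stand for higher solubility and lower numbers for lower solubility), compound 3 `CN(c1ccn(C)n1)c1cnc(NCc2c(F)ccc3c2CCO3)n2cnnc12` reads 130000 nM and stands level with compound 1 `CN(c1ncco1)c1cnc(NCc2c(F)ccc3c2CCO3)n2cnnc12` at 67000 nM (a 1.9-fold higher number from compound 1 to compound 3 (0.29 log units; within the scatter)). Compound 2 `Fc1ccc2c(c1CNc1ncc(Oc3ccccc3)c3nncn13)CCO2` reads 8000 nM and stands well apart (a 16-fold higher number from compound 2 to compound 3 (1.21 log units; beyond the scatter)).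

Compound 4 `O=C(Nc1cnc(NCc2c(F)ccc3c2CCO3)n2cnnc12)c1cccnc1` carries ((pyridin-3-yl)carbonyl)amino in place of methyl(1-methyl-1H-pyrazol-3-yl)amino on an aromatic carbon. Among the measured compounds shown here, no measured compound carries this entering group, so the evidence is indirect. For the measured compounds named here, the closest precedent is compound 2, the only measured compound without a methyl-substituted amino group at that carbon. Its phenoxy group marks a modest step on one side (an 8.4-fold lower number from compound 1 to compound 2 (0.92 log units; beyond the scatter)) and the large step above on the other. The exchange on the nitrogen, between compound 1 and compound 3, stays within the scatter and says little about replacing the whole group.

On this thin ground a modest fall is expected in this assay, with the estimated step being a 5.2-fold lower number from compound 3 to compound 4 (0.72 log units; beyond the scatter) and a wide margin around it. For compound 4 the estimated value is 25000 nM (expected range 5000 nM to 90000 nM).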

Compound 4, solubility: 12000 nM
Beside the measured number, compound 4's estimate is 2.1-fold (0.32 log units) above it; the measured number falls inside the stated range.
By their numbers in this assay, from the lowest: compounds 2 and 4 (each within the scatter of the next); then compounds 1 and 3 (each within the scatter of the next).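

In this assay, the methyl(1-methyl-1H-pyrazol-3-yl)amino group of compound 3 gives way to ((pyridin-3-yl)carbonyl)amino in a large step (an 11-fold lower number from compound 3 to compound 4 (1.03 log units; beyond the scatter)), and the step from the methyl(1,3-oxazol-2-yl)amino group of compound 1 is modest (a 5.6-fold lower number from compound 1 to compound 4 (0.75 log units; beyond the scatter)). Against phenoxy, the new group stands level (a 1.5-fold higher number from compound 2 to compound 4 (0.18 log units; within the scatter)), so two quite different groups on this aromatic carbon now share one reading. Among these four compounds, the two with a methyl-substituted amino group at this carbon stand apart from the two without one, and none of the four goes against this division.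

No evidence at hand accounts for this division. The compounds shown leave open whether the amide hydrogen or the pyridine ring of compound 4 carries the step, and where a plain amine or a morpholine on this carbon would fall.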